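This account rests on a few compounds, and the source may have more. Where it says the series, first, only, none or still open, it means among the compounds named here.

Measured compounds:
compound 1 `COC(=O)CC/C=C\CC[C@H]1C(=O)C[C@@H](O)[C@@H]1/C=C/C[C@@](C)(O)C#CC1=CCCC1` — > 3.16 mg/kg
compound 2 `COC(=O)CC/C=C\CC[C@H]1C(=O)C[C@@H](O)[C@@H]1/C=C/C[C@@](C)(O)/C=C/C1=CCCCC1` — > 3.16 mg/kg

In a functional assay on the whole organism with Rattus norvegicus as the target (on this read-out lower numbers stand for an effect already at smaller amounts and higher numbers for an effect only at larger amounts of compound), compound 1 gives only a limit, > 3.16 mg/kg, not a number. Compound 2 likewise gives only a limit in this assay, > 3.16 mg/kg. Both values therefore sit at the limit of > 3.16 mg/kg in this assay, at which 2 of the 2 values shown sit, so compound 1 stands at a limit with no measured number around it. Among the measured compounds shown here, the one measured step, a step that the two limits leave unreadable from compound 1 to compound 2, stays unreadable for that reason, although it changes the same position that is altered in the new compound.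

Compound 3 `COC(=O)CC/C=C\CC[C@H]1C(=O)C[C@@H](O)[C@@H]1/C=C/C[C@@](C)(O)/C=C/C1(C)CC1` differs from compound 1 by 2-(1-methylcyclopropyl)ethenyl in place of 2-(cyclopent-1-en-1-yl)ethynyl on a saturated chain carbon bound to an oxygen on a saturated carbon and two saturated chain carbons. For the measured compounds named here, no readable step bears on this change; the only related step, from compound 1 to compound 2, tells nothing about its size. The data thus give no reason to expect compound 3 to move away from where compound 1 stands, and the step that the limit leaves unreadable from compound 1 to compound 3 is expected to stay within the scatter. Compound 3 is therefore estimated to show 6 mg/kg in this assay, with a likely range from 2.5 mg/kg to 20 mg/kg, and it is expected that the assay may again report only a limit.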

Compound 3, dose for half-maximal effect: 1.34 mg/kg
For compound 3 the middle estimate is 4.5-fold (0.65 log units) above the measured one, outside the stated range (below it).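

Replacing 2-(cyclopent-1-en-1-yl)ethynyl with 2-(1-methylcyclopropyl)ethenyl on the saturated chain carbon gives an at least 2.3-fold lower number from compound 1 to compound 3 (0.37 log units; beyond the scatter), so in this assay the group at this position can move the read-out beyond the scatter. With the double-bonded chain carbons kept, exchanging only the end group, 1-methylcyclopropyl in place of cyclohex-1-en-1-yl, gives an at least 2.3-fold lower number from compound 2 to compound 3 (0.37 log units; beyond the scatter), which shows that a change of the end group alone is enough to produce a readable step. Both steps give only a minimum size, and neither compound 1 nor compound 2 can be placed any more exactly, since each stands at a limit of the assay: the limit of > 3.16 mg/kg in this assay, at which 2 of the 3 values shown sit.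

As far as these compounds go, whether the methyl on the three-membered ring matters, and whether a plain cyclopropyl or a tert-butyl at the end of the ethenyl would read like compound 3, stays open. The step from compound 1 to compound 2 still cannot be read, so the compounds shown also leave open what the ethynyl or ethenyl link contributes, and how 1-methylcyclopropyl would read on an ethynyl link.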